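This account rests on a few compounds, and the source may have more. Where it says the series, first, only, none or still open, it means among the compounds named here.

Compound 1, with the structure `CN(Cc1ccc(OCCCN)cc1)c1nc2ccc(Oc3ccc(C#N)cc3)cc2s1`, is measured in an assay on cells for inhibition of Voltage-dependent T-type calcium channel subunit alpha-1H (Homo sapiens), read by FLIPR and calcium flux, with stated times of 600 s and 300 s (on this read-out lower numbers stand for stronger inhibition and higher numbers for weaker inhibition), and gives 328000 nM. Compound 2, with the structure `CN(Cc1ccc(OCCCN)cc1)c1nc2ccc(Oc3ccc(F)cc3)cc2s1`, differs from it only in that fluoro replaces cyano on an aromatic carbon, and in this assay compound 2 gives 492000 nM. The step of a 1.5-fold higher number from compound 1 to compound 2 (0.18 log units; within the scatter) shows that the two numbers lie within the usual scatter of each other, so nothing separates compound 2 from compound 1 on the numbers shown; both sit in a very weak range.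

Compound 3, with the structure `CN(Cc1ccc(OCCCN)cc1)c1nc2ccc(Oc3ccc(O)cc3)cc2s1`, is the next step from compound 2: hydroxy in place of fluoro on an aromatic carbon. For the measured compounds named here, the only measured step that bears on this position is the one from compound 1 to compound 2, an exchange of one small group for another at the same aromatic carbon, and it was within the scatter. Going by the values given here, no measured compound carries a hydroxy group here, so no step speaks for hydroxy itself. On that basis the change is expected to move the number little, if at all, beyond the scatter, with an expected step of a 1.2-fold lower number from compound 2 to compound 3 (0.09 log units; within the scatter). Compound 3 is therefore estimated to give about 400000 nM in this assay, within a range from 150000 nM to 1000000 nM.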

Compound 3, half-maximal inhibitory concentration: 165000 nM
Compound 3: the middle estimate sits 2.4-fold (0.38 log units) above what was measured; the measured number falls inside the stated range.
By their numbers in this assay, from the lowest: compounds 3, 1 and 2 (each within the scatter of the next, the first and the last beyond it).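

Changing this aromatic carbon, para to a large group, can move the number beyond the scatter: in this assay, hydroxy in place of fluoro gives a 3.0-fold lower number from compound 2 to compound 3 (0.47 log units; beyond the scatter), a modest step and the first at this position to pass that line. The change from 4-fluorophenoxy to 4-hydroxyphenoxy also adds one hydrogen-bond donor and one hydrogen-bond acceptor, but the hydroxy compound is not separated from the nitrile compound, with a 2.0-fold lower number from compound 1 to compound 3 (0.30 log units; within the scatter), so the result separates hydroxy from fluoro only. No measurement shown gives any reason for the step from fluoro to hydroxy.

The compounds shown leave open whether a methoxy group, an amine or a carboxylic acid on this same aromatic carbon would carry the number further from that of compound 2, or would leave it within the scatter of compound 3. They also leave open whether the hydroxy step would hold with a longer chain in place of the one ending in the amine, since that part is the same in all three compounds.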